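This account rests on a few compounds, and the source may have more. Where it says the series, first, only, none or still open, it means among the compounds named here.

In a functional assay on 143B cells (Homo sapiens) for inhibition, read by MTT assay, with a stated time of 72 h (a higher number here means a weaker inhibitor, a lower number a stronger inhibitor), three compounds that differ only in the group on an amide-type nitrogen give closely matching numbers: compound 1 `O=C(CCC(=O)OCCCCCCSc1ccc([N+](=O)[O-])c2nonc12)Nc1cccc(Cl)c1` gives 2890 nM, compound 2 `Cc1ccc(NC(=O)CCC(=O)OCCCCCCSc2ccc([N+](=O)[O-])c3nonc23)cc1` gives 3250 nM, and compound 3 `COc1ccc(NC(=O)CCC(=O)OCCCCCCSc2ccc([N+](=O)[O-])c3nonc23)cc1` gives 3060 nM. Compound 3 therefore stands level with the other two. Compound 4 `CN(C)CCCNC(=O)CCC(=O)OCCCCCCSc1ccc([N+](=O)[O-])c2nonc12` has 3-(dimethylamino)propyl in place of 4-methoxyphenyl on that nitrogen: 3-(dimethylamino)propyl in place of 4-methoxyphenyl on an amide-type nitrogen. The nearest evidence is a 1.1-fold higher number from compound 1 to compound 3 (0.02 log units; within the scatter) and a 1.1-fold lower number from compound 2 to compound 3 (0.03 log units; within the scatter), both within the scatter. Each of those steps only swaps one substituted phenyl group for another, so neither tests the loss of the ring, and the guidance is weak. No step beyond the scatter is expected in this assay, and the estimated step is a 1.0-fold lower number from compound 3 to compound 4 (0.01 log units; within the scatter). The estimate for compound 4 is 3000 nM, with an expected range from 900 nM to 9000 nM.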

Compound 4, half-maximal inhibitory concentration: 1180 nM
Compound 4: middle estimate off by 2.5-fold (0.41 log units), on the high side; the measured number falls inside the stated range.
By their numbers in this assay, from the lowest: compound 4; then compounds 1, 3 and 2 (each within the scatter of the next).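

In this assay this nitrogen proves sensitive to its group: the substituted phenyl groups gave matching numbers, yet 3-(dimethylamino)propyl gives a 2.6-fold lower number from compound 3 to compound 4 (0.41 log units; beyond the scatter) and a 2.8-fold lower number from compound 2 to compound 4 (0.44 log units; beyond the scatter) and a 2.4-fold lower number from compound 1 to compound 4 (0.39 log units; beyond the scatter) as modest steps beyond the scatter. This change removes the aromatic ring and adds an amine together, so the compounds cannot separate the two. Nothing measured here explains the lower number. Still open, as far as these compounds go, is whether a plain propyl group, without the amine, would give the same number, and whether a longer chain ending in dimethylamino would lower it further.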